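The compounds below may be only part of what the source reports. "The series", "measured", "known", "first", "only" and "open" are said of these compounds alone.

Measured so far:
compound 1 `Cc1[nH]n(-c2nc3cc(Cl)ccc3[nH]2)c(=O)c1Cc1ccccc1` — 87%
compound 2 `Cc1ccc2[nH]c(-n3[nH]c(C)c(Cc4ccccc4)c3=O)nc2c1` — 81%

Both were tested in a functional assay on DU-145 cells (Homo sapiens) for antiproliferative activity, read by WST assay, with a stated time of 7 days, tested at 10 uM; on this read-out higher numbers stand for a stronger effect at the one concentration tested and lower numbers for a weaker effect. Compound 2 gives the smaller of the two numbers shown, but its gap to compound 1 is within the scatter, so the two cannot be told apart on this read-out. Going by the values given here, the only step measured so far is a number 6 percentage points lower from compound 1 to compound 2 (within the scatter), a swap of methyl for chloro on an aromatic carbon that changed nothing beyond the scatter.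

Compound 3 `Cc1[nH]n(-c2nc3cc(C(F)(F)F)ccc3[nH]2)c(=O)c1Cc1ccccc1` is not yet measured. It differs from compound 2 by trifluoromethyl in place of methyl on an aromatic carbon on the same aromatic carbon. Among the compounds with values here, the one step that bears on this swap, from compound 1 to compound 2, showed no effect beyond the scatter, so for this assay a step of similar size is expected: a number 3 percentage points higher from compound 2 to compound 3 (within the scatter). Compound 3 is therefore estimated at 84%, with a range from 70% to 95%.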

Compound 3, a percentage reported as inhibition, at one concentration (the size of the read-out at that concentration, not a potency): 92%
Compound 3: the middle estimate sits 8 percentage points below what was measured; the range from low to high includes it.
By their numbers in this assay, from the lowest: compounds 2, 1 and 3 (each within the scatter of the next, the first and the last beyond it).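

Putting trifluoromethyl in place of methyl on this aromatic carbon gives a number 11 percentage points higher from compound 2 to compound 3 (beyond the scatter) in this assay and so shows, as the earlier pair could not, that the group at this position can move the read-out, if only modestly. The swap of chloro for trifluoromethyl gives a number 5 percentage points higher from compound 1 to compound 3 (within the scatter) and cannot be told apart from no change, which leaves chloro within the scatter of both other groups. Only methyl and trifluoromethyl separate on this read-out, so the three groups do not form a clear ranking.

As far as these compounds go, it stays open whether a different kind of group on this carbon, such as an amine, a carboxylic acid or a nitrile, would hold the effect at this level. The compounds shown offer no measurement that accounts for the gap between methyl and trifluoromethyl.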